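Ring for chain on the aromatic carbon of compound 2

The source may hold more compounds than are shown below. What is called first, only, known or untested is meant among the compounds shown, and "the series" means these compounds.

Measured in an ADME assay on RD cells (Homo sapiens) for cytotoxicity, read by MTT assay, with a stated time of 24 h; a higher number here means that more compound is tolerated, a lower number that less compound is tolerated:
compound 1 `CCc1nc(-c2cc(C)c(OCCC(C)CCN3CCN(c4ccnc(N)c4)C3=O)c(C)c2)no1` gives 15700 nM
compound 2 `CCO/N=C/c1cc(C)c(OCCC(C)CCN2CCN(c3ccnc(N)c3)C2=O)c(C)c1` gives 12900 nM
compound 3 `CCO/N=C/c1ccc(OCC#CCN2CCN(c3ccnc(N)c3)C2=O)cc1` gives > 100000 nM, which is a limit of the assay and not a number
compound 4 `Cc1nc(-c2cc(C)c(OCCC(C)CCN3CCN(c4ccnc(N)c4)C3=O)c(C)c2)no1` is not yet measured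

Compound 2 holds the lowest of the two numbers in this assay; its nearest neighbour is compound 1, and the step of a 1.2-fold lower number from compound 1 to compound 2 (0.09 log units; within the scatter) separates them. Compound 4 differs from compound 2 as follows: a group of 6 heavy atoms (3 carbon, 2 nitrogen, 1 oxygen; one five-membered aromatic ring with 3 hetero atoms) in place of a group of 5 heavy atoms (3 carbon, 1 nitrogen, 1 oxygen; no ring), on an aromatic carbon. For the measured compounds named here, the one measured step that bears on this change is a 1.2-fold lower number from compound 1 to compound 2 (0.09 log units; within the scatter), which ran the other way, exchanging a five-membered aromatic ring with three hetero atoms for a chain on the same aromatic carbon, and stayed within the scatter. Putting a ring of that kind back in place of the chain is therefore expected to give no step beyond the scatter in this assay, the expected step being a 1.2-fold higher number from compound 2 to compound 4 (0.07 log units; within the scatter). Compound 4 is accordingly estimated at 15000 nM, with a range from 7000 nM to 35000 nM.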

Compound 4, half-maximal cytotoxic concentration: 28800 nM
Compound 4: the middle estimate sits 1.9-fold (0.28 log units) below what was measured, within the range that was stated.
By their numbers in this assay, from the lowest: compounds 2, 1 and 4 (each within the scatter of the next, the first and the last beyond it). At a limit, above all of these: compound 3.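

In this assay, for the compounds shown here, the 5-methyl-1,2,4-oxadiazol-3-yl group on this aromatic carbon, meta to two methyl groups, gives the first step beyond the scatter at this position, a 2.2-fold higher number from compound 2 to compound 4 (0.35 log units; beyond the scatter), whereas the earlier exchange between ring and chain stayed within it. Hydrogen in place of methyl on the saturated chain carbon bound to the ring gives a 1.8-fold higher number from compound 1 to compound 4 (0.26 log units; within the scatter), so the two ring compounds are not separated, and only the ring of compound 4 clears the scatter against the chain of compound 2. No measurement shown accounts for this modest step.

On these data alone, whether an amine or a carboxylic acid on this aromatic carbon would move the number further stays open. So does the outcome for a longer chain on the ring.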